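This account rests on a few compounds, and the source may have more. Where it says the series, first, only, none or still open, it means among the compounds named here.

Values in an assay on THP-1 cells for displacement of a labelled ligand from C-C chemokine receptor type 1 (Homo sapiens) (a higher number here means a weaker inhibitor, a lower number a stronger inhibitor), for the measured set:

compound 1 `CC[C@@H](NC(=O)CC(C)C)C(=O)N1CCC(c2ccc(Cl)cc2)CC1`: 152 nM
compound 2 `CC[C@@H](NC(=O)c1ccccc1)C(=O)N1CCC(c2ccc(Cl)cc2)CC1`: 121 nM
compound 3 `CC(C)CC(=O)N[C@@H](C(=O)N1CCC(c2ccc(Cl)cc2)CC1)C(C)C`: 32 nM

Compound 3 holds the lowest number of the three. Compound 2 is the nearest to it, with a gap beyond the scatter, and the widest gap of the set is a 4.8-fold lower number from compound 1 to compound 3 (0.68 log units; beyond the scatter), also beyond the scatter; that step came from a change on the side chain of the core, not on the acyl group.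

Compound 4 `CC(C)[C@@H](NC(=O)CC1CC1)C(=O)N1CCC(c2ccc(Cl)cc2)CC1` is the next point of the series. It differs from compound 3 in one place: cyclopropyl in place of isopropyl on a saturated chain carbon bound to a carbonyl carbon. Going by the values given here, no measured step matches this exchange. Among the compounds with values here, the closest precedent is on the same side of the amide, where a 1.3-fold lower number from compound 1 to compound 2 (0.10 log units; within the scatter) exchanged one acyl group for another of quite different shape and gave a number within the scatter. Within the data shown here, the one step beyond the scatter, a 4.8-fold lower number from compound 1 to compound 3 (0.68 log units; beyond the scatter), concerns the other side of the molecule and says nothing about the acyl group. On this basis the step of a 1.3-fold higher number from compound 3 to compound 4 (0.10 log units; within the scatter) is expected to stay within the scatter, with no clear direction. Compound 4 is therefore estimated to give 40 nM in this assay, with a range from 15 nM to 110 nM.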

Compound 4, half-maximal inhibitory concentration: 46 nM
The estimate for compound 4 lay 1.2-fold (0.06 log units) below the measured number, and the stated range covers the measured number.
By their numbers in this assay, from the lowest: compounds 3 and 4 (each within the scatter of the next); then compounds 2 and 1 (each within the scatter of the next).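

In this assay the place on a saturated chain carbon bound to a carbonyl carbon now has its first reading on the side chain of compound 3: a 1.4-fold higher number from compound 3 to compound 4 (0.16 log units; within the scatter) for cyclopropyl in place of isopropyl, a closed three-membered ring against an open branch of the same heavy-atom count. Together with a 1.3-fold lower number from compound 1 to compound 2 (0.10 log units; within the scatter) on the side chain of compound 1, this gives two exchanges in the acyl part, on two different side chains, that both stay within the scatter, and neither of the two acyl exchanges goes against that reading. Nothing available bears on why the isopropyl and cyclopropyl compounds read alike.

Still open, as far as these compounds go, is whether this acyl part accepts groups of another kind, such as an amine or a carboxylic acid at the end of the chain, or a longer chain or a cyclobutyl ring in place of cyclopropyl. Also open, from the compounds shown here alone, is whether (cyclopropylmethyl)carbonyl on the side chain of compound 1 would keep the same distance from isobutylcarbonyl that it keeps on the side chain of compound 3.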